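The source may report more compounds than this note shows. Statements on the series, on what has been measured and on what is new or still open speak of the compounds shown alone.

Measured compounds:
Compound 1, `COc1ccc(-c2cc(NC(=O)CCC(=O)N(C)CC(=O)NC3CCCCC3)nc(-c3ccc(OC)cc3)n2)cc1`: in an assay on HeLa cells for displacement of a labelled ligand from adenosine receptor A3 (Homo sapiens), read by fluorescence polarization, with a stated time of 30 min (a lower number here means a stronger inhibitor, a higher number a weaker inhibitor), compound 1 gives 52900 nM.
Compound 2, `COc1ccc(-c2cc(NC(=O)COCC(=O)NCC(=O)NC(C)(C)C)nc(-c3ccc(OC)cc3)n2)cc1`: in this assay compound 2 gives 19700 nM.

Among the measured compounds shown here, compound 2 holds the lower of the two numbers so far; the only other value, that of compound 1, is a gap above it that is described as beyond the usual scatter, so compound 2 counts as the stronger of the two in this assay.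

Compound 3, `COc1ccc(-c2cc(NC(=O)COCC(=O)N(C)CC(=O)NC3CCCCC3)nc(-c3ccc(OC)cc3)n2)cc1`, has not yet been measured. It differs from compound 2 in one place: ((cyclohexylcarbamoyl)methyl)(methyl)amino in place of (((tert-butyl)carbamoyl)methyl)amino on a carbonyl carbon. For the measured compounds named here, no step between two measured compounds isolates this change, so there is no measured precedent to lean on. Both numbers in hand are weak, and nothing indicates that this tail change would move the value far in either direction. The expectation for compound 3 is therefore a step from compound 2 that stays close to the scatter, a 1.5-fold higher number from compound 2 to compound 3 (0.18 log units; within the scatter), with a slight lean toward a weaker number. Compound 3 is estimated at 30000 nM, with a plausible range from 10000 nM to 90000 nM in this assay.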

Compound 3, inhibition constant: 23700 nM
Estimate against measurement, compound 3: 1.3-fold (0.10 log units) above, within the range that was stated.
By their numbers in this assay, from the lowest: compounds 2 and 3 (each within the scatter of the next); then compound 1.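

In this assay, among the compounds shown here, ((cyclohexylcarbamoyl)methyl)(methyl)amino in place of (((tert-butyl)carbamoyl)methyl)amino on a carbonyl carbon gives a 1.2-fold higher number from compound 2 to compound 3 (0.08 log units; within the scatter), the first measured step in this set that isolates a single change. The position therefore tolerates this exchange without a separation between the two compounds, even though the entering group brings a six-membered non-aromatic ring of carbon only and carries 1 hydrogen-bond donor where the leaving group carries 2. No measurement at hand offers an explanation for this result.

The exchange bundles two differences, the cyclohexyl for the tert-butyl and the methyl on the nitrogen, so the compounds shown cannot tell whether each alone would leave the number unchanged or whether the two offset each other. For the compounds shown here, they also leave open whether a markedly different group on this carbonyl carbon, such as a carboxylic acid, a primary amine, a phenyl ring or a longer chain, would move the number beyond the scatter, given that the values so far all lie in the same weak range.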